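A few compounds are considered here, and "the series" means these few. Any claim that something is new, unique, unknown or untested is made for them only; others in the source may bear on it.

Three compounds have been measured in an assay on SH-EP1 cells for agonist activity at Neuronal acetylcholine receptor; alpha4/beta2 (Homo sapiens), read by FLIPR and calcium flux; on this read-out lower numbers stand for smaller maximal responses and higher numbers for larger maximal responses:

compound 1 `CC(=O)N1CC2CC(C1)N2` gives 95%
compound 2 `CC(C)C(=O)N1CC2CC(C1)N2` gives 71%
compound 3 `O=C([C@H]1C[C@H]1F)N1CC2CC(C1)N2` gives 110%

All three share the same core and differ only in the group on the carbonyl carbon. Compound 2 stands lowest of the three in this assay: a number 24 percentage points lower from compound 1 to compound 2 (beyond the scatter), and a number 39 percentage points higher from compound 2 to compound 3 (beyond the scatter), both beyond the scatter.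

Compound 4 `C[C@H]1C[C@H]1C(=O)N1CC2CC(C1)N2` has not yet been measured. It differs from compound 2 in one place: 2-methylcyclopropyl in place of isopropyl on a carbonyl carbon. The step that bears most on this is a number 39 percentage points higher from compound 2 to compound 3 (beyond the scatter), where a 2-fluorocyclopropyl replaced the same isopropyl. The related step of a number 15 percentage points higher from compound 1 to compound 3 (beyond the scatter) points the same way, while a number 24 percentage points lower from compound 1 to compound 2 (beyond the scatter) shows isopropyl falling short of methyl. Compound 4 carries a 2-methylcyclopropyl rather than the 2-fluorocyclopropyl of compound 3, so a rise from compound 2 is expected in this assay, though probably a smaller one than the rise to compound 3. The expected step is a number 24 percentage points higher from compound 2 to compound 4 (beyond the scatter). Compound 4 is therefore estimated at 95%, within a range from 75% to 115%.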

Compound 4, largest response reached (Emax), in percent of the reference or control that the assay uses: 93%
Estimate against measurement, compound 4: 2 percentage points above; the measured number falls inside the stated range.
By their numbers in this assay, from the lowest: compound 2; then compounds 4 and 1 (each within the scatter of the next); then compound 3.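

In this assay, a cyclopropyl ring without fluorine also stands above isopropyl on this carbonyl carbon (a number 22 percentage points higher from compound 2 to compound 4 (beyond the scatter)), so the rise seen with compound 3 does not depend on having fluorine on the ring. Fluorine and methyl on the ring are still not interchangeable (a number 17 percentage points lower from compound 3 to compound 4 (beyond the scatter)), and the 2-fluorocyclopropyl keeps the higher response. The 2-methylcyclopropyl cannot be told apart from plain methyl (a number 2 percentage points lower from compound 1 to compound 4 (within the scatter)), although isopropyl falls short of methyl, so the response does not simply fall as this group gains carbon atoms.

Nothing measured here gives a reason for these differences. Still open, on these data alone, is how an unsubstituted cyclopropyl, a cyclobutyl or a longer chain such as n-butyl would read at this carbonyl carbon, and whether the mirror-image 2-methylcyclopropyl gives the same response.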